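The source may hold more compounds than are shown below. What is called first, only, known or untested is meant among the compounds shown, and "the series" means these compounds.

Compound 1 `CC1(/C=C/c2ccccc2)C=CC(=O)O1`: 89800 nM
Compound 2 `COc1ccccc1/C=C/C1(C)C=CC(=O)O1`: 41100 nM

In a functional assay on U-251 cells (Homo sapiens) for inhibition, read by sulforhodamine B assay, with a stated time of 48 h (on this read-out higher numbers stand for weaker inhibition of growth and lower numbers for stronger inhibition of growth), compound 1 gives 89800 nM, the highest of the two numbers measured. Compound 2 gives 41100 nM, and the step of a 2.2-fold lower number from compound 1 to compound 2 (0.34 log units; beyond the scatter) comes from methoxy in place of hydrogen on an aromatic carbon. Compound 3 `COc1cccc(/C=C/C2(C)C=CC(=O)O2)c1` differs from compound 1 by methoxy in place of hydrogen on an aromatic carbon. Going by the values given here, the only measured step that bears on this change is a 2.2-fold lower number from compound 1 to compound 2 (0.34 log units; beyond the scatter), a modest one toward stronger growth inhibition. For compound 3 a similarly modest step in the same direction is expected, a 1.8-fold lower number from compound 1 to compound 3 (0.25 log units; within the scatter). Compound 3 is therefore estimated at 50000 nM, most likely between 25000 nM and 100000 nM.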

Compound 3, concentration for total growth inhibition: 37600 nM
Compound 3: middle estimate off by 1.3-fold (0.12 log units), on the high side; measured number inside the range.
By their numbers in this assay, from the lowest: compounds 3 and 2 (each within the scatter of the next); then compound 1.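

Methoxy in place of hydrogen, here meta to a group of 9 heavy atoms, gives a 2.4-fold lower number from compound 1 to compound 3 (0.38 log units; beyond the scatter) and so shows that the change is not tied to a single place on the aromatic ring. Compound 2 and compound 3 lie within the scatter of each other, so these two placements of methoxy cannot be told apart here. Nothing available explains the shift. Going by these compounds, whether an amine, a carboxylic acid or a longer chain such as ethoxy at this position would move the number further remains open.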